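A few compounds are considered here, and "the series" means these few. Any claim that something is new, unique, unknown or untested is made for them only; others in the source may bear on it.

Compound 3 `Cn1c(=O)c(C(=O)Nc2ccccc2N)c(O)c2ccccc21` stands highest of the three measured compounds in a functional assay, with a stated time of 60 min, tested at 0.5 mM (on this read-out higher numbers stand for a stronger effect at the one concentration tested and lower numbers for a weaker effect), where compound 3 gives 41.4%. Within the data shown here, compound 2 `NCCCCCCNC(=O)c1c(O)c2ccccc2n(-c2ccccc2)c1=O` gives 28.1%, and compound 1 `COC(=O)c1c(O)c2ccccc2n(-c2ccccc2)c1=O` gives 19.3%; the only measured step, a number 8.8 percentage points higher from compound 1 to compound 2 (within the scatter), concerns a change on a carbonyl carbon and not the aromatic nitrogen. Compound 4 `Nc1ccccc1NC(=O)c1c(O)c2ccccc2n(-c2ccccc2)c1=O` differs from compound 3 by phenyl in place of methyl on an aromatic nitrogen. Among the measured compounds shown here, no measured step bears on this change: compounds 1 and 2 carry phenyl on the aromatic nitrogen, but they also differ from compound 3 elsewhere, so their lower values cannot be assigned to that group. In this assay the step of a number 5.4 percentage points lower from compound 3 to compound 4 (within the scatter) is therefore expected to be small, with no confident direction. Compound 4 is estimated at 36%, within 20% to 52%.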

Compound 4, a percentage reported as activity, at one concentration (the size of the read-out at that concentration, not a potency): 34.7%
Compound 4: the middle estimate sits 1.3 percentage points above what was measured; low and high end bracket the measured number.
By their numbers in this assay, from the lowest: compounds 1, 2, 4 and 3 (each within the scatter of the next, the first and the last beyond it).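

On the aromatic nitrogen, phenyl in place of methyl now has a step of its own in this assay, and that step is a number 6.7 percentage points lower from compound 3 to compound 4 (within the scatter) and gives no firm direction. With phenyl held on that nitrogen, 2-aminophenyl in place of 6-aminohexyl on the amide-type nitrogen gives a number 6.6 percentage points higher from compound 2 to compound 4 (within the scatter) while (2-aminophenyl)amino in place of methoxy on the carbonyl carbon gives a number 15.4 percentage points higher from compound 1 to compound 4 (beyond the scatter) and alone among the three clears the scatter. From the compounds shown here alone, whether an ethyl group or a longer chain on the aromatic nitrogen would behave like methyl or phenyl remains open. Nothing shown gives a cause for any of these steps.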